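A Fluorophenyl Replaces Methoxyphenyl on the Double-Bonded Chain

The source may report more compounds than this note shows. Statements on the series, on what has been measured and on what is new or still open speak of the compounds shown alone.

Three compounds have so far been measured in a functional assay on HeLa cells (Homo sapiens) for cytotoxicity, read by WST assay, with a stated time of 48 h; on this read-out higher numbers stand for weaker inhibition and lower numbers for stronger inhibition:

compound 1 `COc1ccc(/C=C/C[C@H]2C[C@@H]([C@@H](O)c3ccccc3)CO[C@@H]2c2ccccc2)cc1`: 8300 nM
compound 2 `COc1ccccc1/C=C/C[C@H]1C[C@@H]([C@@H](O)c2ccccc2)CO[C@@H]1c1ccccc1`: 14700 nM
compound 3 `COc1cccc(/C=C/C[C@H]2C[C@@H]([C@@H](O)c3ccccc3)CO[C@@H]2c2ccccc2)c1`: 10900 nM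

Compound 3 holds the second highest of the three numbers. Its nearest neighbour is compound 1, with a 1.3-fold higher number from compound 1 to compound 3 (0.12 log units; within the scatter), and the furthest is compound 2, with a 1.3-fold lower number from compound 2 to compound 3 (0.13 log units; within the scatter). Both steps lie within the scatter, so the three compounds cannot be ordered against one another.

Compound 4 `O[C@@H](c1ccccc1)[C@H]1CO[C@H](c2ccccc2)[C@@H](C/C=C/c2ccc(F)cc2)C1` differs from compound 3 in one place: 4-fluorophenyl in place of 3-methoxyphenyl on a double-bonded chain carbon bound to a double-bonded chain carbon. The measured steps that bear on this position all move a methoxyphenyl from one substitution pattern to another, namely a 1.8-fold higher number from compound 1 to compound 2 (0.25 log units; within the scatter), a 1.3-fold higher number from compound 1 to compound 3 (0.12 log units; within the scatter) and a 1.3-fold lower number from compound 2 to compound 3 (0.13 log units; within the scatter), and each stays within the scatter. Going by the values given here, no measured pair exchanges the methoxy group for fluorine, so there is no direct precedent for that part of the change. Given how little this position has moved the numbers, compound 4 is expected to show a 1.1-fold lower number from compound 3 to compound 4 (0.04 log units; within the scatter), that is, no step beyond the scatter. Compound 4 is therefore estimated at 10000 nM, with a range from 4000 nM to 25000 nM.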

Compound 4, half-maximal inhibitory concentration: 8340 nM
Compound 4: the middle estimate sits 1.2-fold (0.08 log units) above what was measured; measured number inside the range.
By their numbers in this assay, from the lowest: compounds 1, 4, 3 and 2 (each within the scatter of the next).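

Going by these compounds alone, compound 4 brings the first change of substituent rather than of methoxy placement, and fluoro in place of methoxy on an aromatic carbon leaves the number within the scatter (a 1.0-fold higher number from compound 1 to compound 4 (0.00 log units; within the scatter)). The comparisons with the other two methoxyphenyl compounds also stay within the scatter (a 1.3-fold lower number from compound 3 to compound 4 (0.12 log units; within the scatter); a 1.8-fold lower number from compound 2 to compound 4 (0.25 log units; within the scatter)). Thus, on a double-bonded chain carbon bound to a double-bonded chain carbon, an aryl group with no hydrogen-bond acceptor reads the same as those with one, and nothing available explains this.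

The four compounds leave open whether any group at this place can produce a step beyond the scatter, such as a phenyl ring bearing an amine or a carboxylic acid. They also leave open how 2-fluorophenyl or 3-fluorophenyl would compare with 4-fluorophenyl.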